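Compound 4 carbamoyl in place of ethylsulfonyl: expected permeability

The source may report more compounds than this note shows. Statements on the series, on what has been measured and on what is new or still open speak of the compounds shown alone.

Measured compounds:
compound 1 `Cn1cncc1CN1CC(N(CC2CCN(C(=O)CC(C)(C)C)CC2)S(=O)(=O)c2ccccn2)Cc2cc(C#N)ccc21` 0.5 10^-6 cm/s
compound 2 `CCCC(=O)N1CCC(CN(C2Cc3cc(C#N)ccc3N(Cc3cncn3C)C2)S(=O)(=O)c2ccccn2)CC1` 0.5 10^-6 cm/s
compound 3 `CCS(=O)(=O)N1CCC(CN(C2Cc3cc(C#N)ccc3N(Cc3cncn3C)C2)S(=O)(=O)c2ccccn2)CC1` 0.1 10^-6 cm/s

The three compounds share one core and differ only in the group on an amine nitrogen in a ring. In an ADME assay on Caco-2 cells (Homo sapiens) for permeability, in the apical to basolateral direction (a higher number here means that the compound crosses the layer faster, a lower number that the compound crosses the layer more slowly), compound 1 gives 0.5 10^-6 cm/s, and compound 2, with no change at the digits printed from compound 1 to compound 2 (within the scatter), gives 0.5 10^-6 cm/s. Compound 3 gives 0.1 10^-6 cm/s, the lowest of the three numbers, reached by a 5.0-fold lower number from compound 1 to compound 3 (0.70 log units; beyond the scatter) and equally by a 5.0-fold lower number from compound 2 to compound 3 (0.70 log units; beyond the scatter).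

Compound 4 `Cn1cncc1CN1CC(N(CC2CCN(C(=O)Nc3ccc(Br)cc3)CC2)S(=O)(=O)c2ccccn2)Cc2cc(C#N)ccc21` is not yet measured. It differs from compound 3 by (4-bromophenyl)carbamoyl in place of ethylsulfonyl on an amine nitrogen in a ring. Going by the values given here, the steps that bear on this are the two that lead into compound 3, both of which replaced a group with a carbonyl by ethylsulfonyl and both of which lowered the number by the same modest amount. Among the compounds with values here, the step to compound 4 reverses that: the ethylsulfonyl leaves and a group with a carbonyl enters again, though a larger one bearing a six-membered aromatic ring, a bromine and a hydrogen-bond donor, which no measured step covers. The account therefore expects the number for compound 4 to rise by a 5.0-fold higher number from compound 3 to compound 4 (0.70 log units; beyond the scatter), back toward the level of compound 1 and compound 2. Compound 4 is estimated at 0.5 10^-6 cm/s, with a range from 0.15 10^-6 cm/s to 1.5 10^-6 cm/s.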

Compound 4, apparent permeability: 0.6 10^-6 cm/s
Beside the measured number, compound 4's estimate is 1.2-fold (0.08 log units) below it, within the range that was stated.
By their numbers in this assay, from the lowest: compound 3; then compounds 1, 2 and 4 (each within the scatter of the next).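

At the amine nitrogen in the ring, compound 4 shows that a larger group, with a six-membered aromatic ring, a bromine and a hydrogen-bond donor, leaves the number in this assay level with the two smaller carbonyl groups, with a 1.2-fold higher number from compound 1 to compound 4 (0.08 log units; within the scatter) and a 1.2-fold higher number from compound 2 to compound 4 (0.08 log units; within the scatter). Against the ethylsulfonyl, the same group gives a 6.0-fold higher number from compound 3 to compound 4 (0.78 log units; beyond the scatter), so among these four compounds the three with a carbonyl on this nitrogen stand together and compound 3, with its sulfonyl group, is the one exception. That holds across quite different carbonyl groups, neopentylcarbonyl, propylcarbonyl and (4-bromophenyl)carbamoyl, but no measurement shown here accounts for the gap between them and the ethylsulfonyl.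

Going by these compounds alone, with ethylsulfonyl the only sulfonyl group in the set, it stays open whether a phenylsulfonyl on the same nitrogen would give a number like that of compound 3 or like that of compound 4. Going by these compounds, it also stays open what the bromine and the amide hydrogen each contribute, a question that a plain phenylcarbamoyl or a benzoyl group at this place would address.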